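The source may report more compounds than this note shows. Statements on the series, on what has been measured and on what is new or still open speak of the compounds shown alone.

In a functional assay on HCT-116 cells (Homo sapiens) for cytotoxicity, read by MTT assay, with a stated time of 72 h (a lower number here means a stronger inhibitor, a higher number a weaker inhibitor), compound 1 `CC(C)NC(=S)N/N=C1\CC(c2ccc(O)cc2)Oc2cc(O)ccc21` gives 38200 nM. Going by the values given here, compound 2 `CC(C)(C)NC(=S)N/N=C1\CC(c2ccc(O)cc2)Oc2cc(O)ccc21` gives 25900 nM, which lies within the scatter of the value for compound 1, so the two numbers known so far set no order between these compounds. Compound 3 `Oc1ccc(C2C/C(=N\NC(=S)N3CCCC3)c3ccc(O)cc3O2)cc1` keeps the shared core and differs from compound 2 as follows: pyrrolidin-1-yl in place of (tert-butyl)amino on a thiocarbonyl carbon. In words, pyrrolidin-1-yl stands in place of (tert-butyl)amino on a thiocarbonyl carbon. Among the compounds with values here, only one measured step bears on this change, and only loosely: a 1.5-fold lower number from compound 1 to compound 2 (0.17 log units; within the scatter). That step exchanged one open chain group for another, while the change now at hand brings in a ring and removes a hydrogen-bond donor. Within the data shown here, no measured compound shows what such a change does. On the small size of that single step, no change beyond the scatter is expected in this assay, and the range is kept wide. The expected step is a 1.2-fold higher number from compound 2 to compound 3 (0.06 log units; within the scatter). Compound 3 is estimated at 30000 nM, with an expected range of 12000 nM to 75000 nM.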

Compound 3, half-maximal inhibitory concentration: 52300 nM
Compound 3: the middle estimate sits 1.7-fold (0.24 log units) below what was measured; measured number inside the range.
By their numbers in this assay, from the lowest: compounds 2, 1 and 3 (each within the scatter of the next, the first and the last beyond it).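

On the thiocarbonyl carbon, the exchange of (tert-butyl)amino for pyrrolidin-1-yl in this assay gives the first step beyond the scatter among these compounds: a 2.0-fold higher number from compound 2 to compound 3 (0.31 log units; beyond the scatter), though the step is modest. The same ring set against isopropylamino gives a 1.4-fold higher number from compound 1 to compound 3 (0.14 log units; within the scatter), so the exchange clears the scatter only when measured from one of the two open chain groups. The position therefore accepts a five-membered non-aromatic ring in which the hydrogen-bond donor of the open amino groups is gone, and the number moves only modestly on these three compounds. Nothing measured here offers an explanation for this step.

The ring and the loss of the donor arrive together in compound 3, so the compounds shown cannot tell which of the two goes with the step. Diethylamino, an open chain group that also lacks the amino hydrogen, would bear on that question, while piperidin-1-yl or morpholin-4-yl would show whether ring size or a ring oxygen matters at this place.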